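Swapping pyridin-2-yl for butyl: an expected shift

A few compounds are considered here, and "the series" means these few. Any claim that something is new, unique, unknown or untested is made for them only; others in the source may bear on it.

Compound 1 `Cc1ccc(-c2cn(CCCN3C(=O)COc4ccccc43)nn2)cc1`: 1120 nM
Compound 2 `O=C1COc2ccccc2N1CCCn1cc(-c2ccccn2)nn1`: 4800 nM

In a functional assay on MDA-MB-231 cells (Homo sapiens) for antiproliferative activity, read by sulforhodamine B assay, with a stated time of 48 h (a lower number here means a stronger inhibitor of growth, a higher number a weaker inhibitor of growth), compound 2 gives 4800 nM, the higher of the two numbers, which makes it the weaker growth inhibitor of the pair. Compound 3 `CCCCc1cn(CCCN2C(=O)COc3ccccc32)nn1` keeps the shared core and has butyl in place of pyridin-2-yl on an aromatic carbon. Going by the values given here, only one measured step bears on this change: a 4.3-fold higher number from compound 1 to compound 2 (0.63 log units; beyond the scatter). It is a modest step beyond the scatter, made at the same place, so this place does respond to a change of group. Butyl is neither of the two groups tested there, which leaves that step as only a rough guide. A small step towards a lower number is therefore expected in this assay, smaller than the measured one. The estimated step is a 2.2-fold lower number from compound 2 to compound 3 (0.34 log units; beyond the scatter). Compound 3 is expected at 2200 nM, with an estimated range of 800 nM to 6000 nM.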

Compound 3, concentration for 50% growth inhibition: 3600 nM
Compound 3: middle estimate off by 1.6-fold (0.21 log units), on the low side, within the range that was stated.
By their numbers in this assay, from the lowest: compound 1; then compounds 3 and 2 (each within the scatter of the next).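

In this assay, butyl in place of pyridin-2-yl gives a 1.3-fold lower number from compound 2 to compound 3 (0.12 log units; within the scatter) and stays within the scatter, so an open chain and a six-membered aromatic ring with a ring nitrogen cannot be told apart at this place. Butyl in place of 4-methylphenyl gives a 3.2-fold higher number from compound 1 to compound 3 (0.51 log units; beyond the scatter) and lies beyond the scatter, leaving compound 1 as the strongest growth inhibitor of the three. An aromatic ring at this place is therefore not enough on its own to match compound 1, as compound 2 shows. From the compounds shown here alone, whether a plain phenyl, a 4-methoxyphenyl or a longer chain such as octyl would sit nearer compound 1 or nearer compound 2 and compound 3 remains open. No measurement offered here explains why these groups compare as they do.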